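The compounds below may be only part of what the source reports. "The series", "measured", "known", "first", "only" and "open" are said of these compounds alone.

Compounds measured so far in a functional assay on HeLa cells (Homo sapiens) for cytotoxicity, read by WST assay, with a stated time of 48 h, tested at 100 uM; on this read-out lower numbers stand for less inhibition and higher numbers for more inhibition at the one concentration tested (going by the name of the read-out):

Compound 1 `O[C@@H](c1ccccc1)[C@H]1CO[C@H](c2ccccc2)[C@@H](C/C=C/c2ccncc2)C1` gives 34% in this assay.
Compound 2 `COc1ccc(/C=C/C[C@@H]2C[C@@H]([C@@H](OC)c3ccc(OC)c(OC)c3)CO[C@H]2c2ccc(OC)c(OC)c2)cc1OC` gives 34%.
Compound 3 `COc1ccc(/C=C/C[C@@H]2C[C@@H]([C@@H](OC(C)=O)c3ccc(OC)c(OC)c3)CO[C@H]2c2ccc(OC)c(OC)c2)cc1OC` gives 48%.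

Compound 1 and compound 2 show the same value at the digits read, and the two of them sit at the low end of the three numbers. Within the data shown here, compound 3 stands apart from compound 1 by a gap of the same size as the one change that was measured: a number 14 percentage points higher from compound 2 to compound 3 (beyond the scatter). Among the measured compounds shown here, that step, acetyl in place of methyl on an oxygen on a saturated carbon, is the only step in this set, and it concerns a different part of the molecule from the change now considered.

Compound 4 `O[C@@H](c1ccccc1)[C@H]1CO[C@H](c2ccccc2)[C@@H](C/C=C/c2cccnc2)C1` differs from compound 1 only in the aromatic ring at the end of the chain: pyridin-3-yl in place of pyridin-4-yl on a double-bonded chain carbon bound to a double-bonded chain carbon. The shared core, the hydroxyl group and the double-bonded chain are kept. For the measured compounds named here, nothing in the measured compounds speaks to moving the nitrogen within this ring, so there is no measured step that bears on it, and no step beyond the scatter is expected in this assay. Compound 4 is therefore estimated at 36%, with a range from 20% to 52%, which means an expected step of a number 2 percentage points higher from compound 1 to compound 4 (within the scatter).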

Compound 4, a percentage reported as inhibition, at one concentration (the size of the read-out at that concentration, not a potency): 4%
For compound 4 the middle estimate is 32 percentage points above the measured one, and the stated range ends above it.
By their numbers in this assay, from the lowest: compound 4; then compounds 1 and 2 (each within the scatter of the next); then compound 3.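

In this assay, the end of the chain proves to be a sensitive place in this series: pyridin-3-yl in place of pyridin-4-yl on a double-bonded chain carbon bound to a double-bonded chain carbon gives a number 30 percentage points lower from compound 1 to compound 4 (beyond the scatter). Among these compounds, the two groups have the same atoms, the same counts of hydrogen-bond donors and acceptors and no net charge, so the read-out here responds to how the same atoms are joined, which the only earlier step, on an oxygen on a saturated carbon, could not show. Nothing available accounts for this drop, and the data give no explanation of it.

The compounds shown leave open how pyridin-2-yl, or a pyrimidine ring, would read at this place, and so whether the value follows the place of the ring nitrogen or is particular to the pyridin-4-yl group. They also leave open whether the same exchange would have a similar effect on a compound carrying methoxy groups on its other aromatic rings, such as compound 2, since this single step was read only on the unsubstituted rings of compound 1.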